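The source may report more compounds than this note shows. Statements on the series, on what has been measured and on what is new or still open speak of the compounds shown alone.

Going by the values given here, in an ADME assay on cytosol from liver (strain IGS SD) for pharmacokinetics, with aldehyde oxidase 1 (Rattus norvegicus) as the target, read by LC-MS, with a stated time of 120 min, tested at 1 uM (on this read-out higher numbers stand for a longer-lived compound and lower numbers for a shorter-lived compound), the three measured members carry a thioether-linked pair of bicyclic cores and differ only in the amine on one aromatic carbon. Compound 1 `Cn1cc(-c2ccc3nnc(Sc4ccc5ncc(N6CCC(N)C6)cc5c4)n3c2)cn1` gives a value that is a limit of this assay rather than a number, namely > 8.33 h (the limit of > 8.33 h in this assay, at which 1 of the 3 values shown sits). Compound 2 `Cn1cc(-c2ccc3nnc(Sc4ccc5ncc(NC6CCOC6)cc5c4)n3c2)cn1` gives 1.35 h in this assay, and compound 3 `Cn1cc(-c2ccc3nnc(Sc4ccc5ncc(NCC6CCOC6)cc5c4)n3c2)cn1` gives 2.15 h, the higher of the two numbers, though a 1.6-fold higher number from compound 2 to compound 3 (0.20 log units; within the scatter). The two steps away from compound 1 are larger: an at least 6.1-fold lower number from compound 1 to compound 2 (0.79 log units; beyond the scatter) and an at least 3.8-fold lower number from compound 1 to compound 3 (0.58 log units; beyond the scatter).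

Compound 4 `Cn1cc(-c2ccc3nnc(Sc4ccc5ncc(NCCO)cc5c4)n3c2)cn1` differs from compound 3 by hydroxymethyl in place of oxolan-3-yl on a saturated chain carbon bound to a nitrogen on an aromatic ring. Among the compounds with values here, no measured step touches this kind of change; the nearest comparison, a 1.6-fold higher number from compound 2 to compound 3 (0.20 log units; within the scatter), alters only the link to the same oxolane and stays within the scatter, so a step from compound 3 to compound 4 of no more than the scatter is expected, with a 1.1-fold lower number from compound 3 to compound 4 (0.03 log units; within the scatter) as the estimate. Compound 4 is therefore expected to give about 2 h in this assay, within a range from 0.9 h to 4.5 h.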

Compound 4, half-life: 3.82 h
The estimate for compound 4 lay 1.9-fold (0.28 log units) below the measured number; low and high end bracket the measured number.
By their numbers in this assay, from the lowest: compounds 2, 3 and 4 (each within the scatter of the next, the first and the last beyond it). At a limit, above all of these: compound 1.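

In this assay, replacing the (oxolan-3-yl)methyl group with 2-hydroxyethyl removes the ring and adds a hydrogen-bond donor, yet the outcome stays within the scatter, with a 1.8-fold higher number from compound 3 to compound 4 (0.25 log units; within the scatter). Going by these compounds alone, measured against the oxolan-3-yl group on the same nitrogen, the open chain does stand apart, with a 2.8-fold higher number from compound 2 to compound 4 (0.45 log units; beyond the scatter), the first step beyond the scatter that does not involve compound 1. The remaining gap, an at least 2.1-fold lower number from compound 1 to compound 4 (0.33 log units; beyond the scatter), is only a bound, as compound 1 stands at a limit of the assay: the limit of > 8.33 h in this assay, at which 1 of the 4 values shown sits.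

These compounds cannot separate the loss of the ring from the gain of the hydroxyl group as the source of the step from the oxolan-3-yl group. As far as these compounds go, it also remains open how a longer 3-hydroxypropyl chain, or a 2-aminoethyl chain carrying a primary amine in place of the hydroxyl group, would read at this position.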